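This account rests on a few compounds, and the source may have more. Where it says the series, first, only, none or still open, it means among the compounds named here.

Compound 1, `CCn1c(C(=O)N[C@H](C)CO)ccc1C(CC)(CC)c1ccc(OCS(=O)(=O)c2ccccc2)c(C)c1`, is the compound from which the comparison starts. In a functional assay on MCF7 cells (Homo sapiens) for antiproliferative activity, read by MTT assay, with a stated time of 24 h (on this read-out higher numbers stand for weaker inhibition and lower numbers for stronger inhibition), compound 1 gives 10600 nM, the lowest of the two numbers in this series. Compound 2, `CCn1c(C(=O)N[C@@H](C)C(=O)O)ccc1C(CC)(CC)c1ccc(OCS(=O)(=O)c2ccccc2)c(C)c1`, gives 35500 nM in this assay, and the step of a 3.3-fold higher number from compound 1 to compound 2 (0.52 log units; beyond the scatter) carries the change from 1-(hydroxymethyl)ethyl to 1-carboxyethyl on the amide-type nitrogen. Compound 3, `CCn1c(C(=O)N[C@H](C)C(=O)O)ccc1C(CC)(CC)c1ccc(OCS(=O)(=O)c2ccccc2)c(C)c1`, is reported only as a limit of this assay, > 50000 nM. Between compound 2 and compound 3 the step of an at least 1.4-fold higher number from compound 2 to compound 3 (0.14 log units; that floor lies within the scatter) rests on (the fact that compounds 2 and 3 differ only in the configuration as drawn), and it is bounded by the limit of > 50000 nM in this assay, at which 1 of the 3 values shown sits.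

Compound 4, `CCn1c(C(=O)N[C@@H](CC(=O)O)C(=O)O)ccc1C(CC)(CC)c1ccc(OCS(=O)(=O)c2ccccc2)c(C)c1`, differs from compound 1 as follows: 1,2-dicarboxyethyl in place of 1-(hydroxymethyl)ethyl on an amide-type nitrogen. The measured steps that bear on this are a 3.3-fold higher number from compound 1 to compound 2 (0.52 log units; beyond the scatter) and an at least 4.7-fold higher number from compound 1 to compound 3 (0.67 log units; beyond the scatter), both of which replace the hydroxymethyl by a carboxy group and both of which move to higher numbers beyond the scatter. Compound 4 carries the carboxy group of those steps and a second carboxy group on the chain, so the expected step in this assay is toward a higher number again, a 4.2-fold higher number from compound 1 to compound 4 (0.63 log units; beyond the scatter), with a real chance that only a limit is reported. The estimate for compound 4 is therefore 45000 nM, with a range from 15000 nM to 150000 nM.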

Compound 4, half-maximal inhibitory concentration: > 50000 nM
Compound 4: a limit, no number; the forecaster's own chance of this, stated with the estimate: 45%; middle value at least 1.1-fold (0.04 log units) from the limit.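

In this assay compound 4 is reported only as a limit, > 50000 nM, so the new result gives a floor and not a number. Placing 1,2-dicarboxyethyl on the amide-type nitrogen in place of 1-(hydroxymethyl)ethyl gives an at least 4.7-fold higher number from compound 1 to compound 4 (0.67 log units; beyond the scatter), so a chain with two carboxy groups joins the chains with one in lying beyond the scatter from compound 1, which keeps the lowest number of the series. The added carboxy group itself shows no readable effect: the floor of an at least 1.4-fold higher number from compound 2 to compound 4 (0.14 log units; that floor lies within the scatter) lies within the scatter, and the step from compound 3 to compound 4 cannot be read, since both values are limits.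

How far the numbers of compound 3 and compound 4 truly lie from the others stays open, since the series reaches its ceiling here: the limit of > 50000 nM in this assay, at which 2 of the 4 values shown sit. The compounds shown also do not tell whether a primary amine or a methyl ester in place of the carboxy group, or a longer chain ending in hydroxymethyl, would stay close to compound 1 on the amide-type nitrogen.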